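The source may hold more compounds than are shown below. What is called first, only, known or untested is meant among the compounds shown, and "the series" means these compounds.

Compound 2 `COC(=O)/C=C/c1ccncc1-c1ccc2ccccc2c1` is the only one of this small set with a reported number: in a functional assay on HCT-116 cells (Homo sapiens) for inhibition, read by MTT assay, with a stated time of 72 h (a higher number here means a weaker inhibitor of growth, a lower number a stronger inhibitor of growth), compound 2 gives 350 nM. Compound 1 `O=C(/C=C/c1ccncc1-c1ccc2[nH]ccc2c1)N1CCOCC1` has no result in this assay, recorded as "not determined" (no result reported). Compound 3 `CNC(=O)/C=C/c1ccncc1-c1ccc2cnn(C)c2c1` is likewise recorded in this assay as "not determined" (no result reported). Compound 4 `CCOC(=O)/C=C/c1ccncc1-c1ccc2ccccc2c1` has not yet been measured in this assay. The change from compound 2 to compound 4 is methyl in place of hydrogen on a saturated chain carbon bound to an oxygen next to a carbonyl group. For the measured compounds named here, with no measured step of this kind available, the expected step of a 1.1-fold higher number from compound 2 to compound 4 (0.06 log units; within the scatter) is small and within the usual scatter, in no particular direction. Compound 4 is therefore expected to give about 400 nM in this assay, estimated between 150 nM and 1100 nM.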

Compound 4, concentration for 50% growth inhibition: 910 nM
For compound 4 the middle estimate is 2.3-fold (0.36 log units) below the measured one, and the stated range covers the measured number.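

In this assay, for the compounds shown here, methyl in place of hydrogen on a saturated chain carbon bound to an oxygen next to a carbonyl group gives a 2.6-fold higher number from compound 2 to compound 4 (0.41 log units; beyond the scatter) as the first measured step at this position. This shows that going from methoxycarbonyl to ethoxycarbonyl weakens growth inhibition modestly, so this position is sensitive even to this small change. Nothing available accounts for the step. Still open, on these data alone, is whether a longer chain, such as propoxycarbonyl, would weaken growth inhibition further. Also open, as far as these compounds go, is how a carboxylic acid would compare at this place.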